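Chain Lengthening and Cell Toxicity in Four Related Compounds

The compounds below may be only part of what the source reports. "The series", "measured", "known", "first", "only" and "open" are said of these compounds alone.

Compounds 1, 2 and 3 have so far been examined in an ADME assay on Vero cells (Chlorocebus sabaeus) for cytotoxicity, read by microscopy, with a stated time of 6 days; on this read-out higher numbers stand for lower toxicity in this test and lower numbers for higher toxicity in this test. Compound 1 `CCCCCNc1cnc(C(=O)NCc2ccccc2)cn1` gives > 100000 nM in this assay, a value that is a limit of the assay rather than a number. Compound 2 `CCCCNc1cnc(C(=O)NCc2ccccc2)cn1` likewise gives > 100000 nM in this assay, again a limit. Compound 3 `CCCCCCNc1nccnc1C(=O)NCc1ccccc1` gives > 100000 nM in this assay, also a limit.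

Compound 1 differs from compound 2 by methyl in place of hydrogen on a saturated chain carbon, four bonds along the chain from a nitrogen on an aromatic ring. The resulting step, a step that the two limits leave unreadable from compound 2 to compound 1, is one that the two limits leave unreadable, so its size is not known. The difference between the core of compound 2 and the core of compound 3 is not broken down here.

Compound 4 `CCCCCCCNc1nccnc1C(=O)NCc1ccccc1` has not yet been measured in this assay. It differs from compound 3 by methyl in place of hydrogen on a saturated chain carbon, six bonds along the chain from a nitrogen on an aromatic ring. This is the same kind of change as that from compound 2 to compound 1, but the place is not the same: there the methyl enters four bonds along the chain from a nitrogen on an aromatic ring, here six bonds along the chain from a nitrogen on an aromatic ring.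

What is known of this assay across the series is the limit of > 100000 nM in this assay, at which 3 of the 3 values shown sit. Resting on that, the step from compound 3 to compound 4 is expected to be a step that the limit leaves unreadable from compound 3 to compound 4, with compound 4 most likely reported as a limit again. Compound 4 is therefore estimated at 150000 nM, expected to fall between 70000 nM and 400000 nM.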

Compound 4, minimum cytotoxic concentration: > 100000 nM
Compound 4 gave a limit, no number; the forecaster's own chance of this, stated with the estimate: 85%; the middle value does not contradict the limit.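

Compound 4 gives > 100000 nM in this assay as a limit of the assay, not a number. Compound 3 also stands at a limit, so no step can be read from compound 3 to compound 4. The compounds shown leave open at what concentration any of them would harm the cells in this assay and whether lengthening the chain changes that at all.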